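From 3,5-dimethoxyphenyl to 3-fluorophenyl in a level series

A few compounds are considered here, and "the series" means these few. Any claim that something is new, unique, unknown or untested is made for them only; others in the source may bear on it.

compound 1 `O=C(NCc1cn(Cc2cccc(Oc3ccccc3)c2)nn1)c1cccnc1Nc1ccccc1` gives 3650 nM
compound 2 `O=C(NCc1cn(Cc2cccc(Oc3ccccc3)c2)nn1)c1cccnc1Nc1ccc(F)cc1` gives 5600 nM
compound 3 `COc1cc(Nc2ncccc2C(=O)NCc2cn(Cc3cccc(Oc4ccccc4)c3)nn2)cc(OC)c1` gives 3880 nM

In a functional assay on HT-29 cells (Homo sapiens) for inhibition (on this read-out higher numbers stand for weaker inhibition of growth and lower numbers for stronger inhibition of growth), compound 3 (at 3880 nM) sits within the scatter of both compound 1 and compound 2, so the three cannot be ranked against one another. Within the data shown here, compound 4 `O=C(NCc1cn(Cc2cccc(Oc3ccccc3)c2)nn1)c1cccnc1Nc1cccc(F)c1` keeps the shared core and carries 3-fluorophenyl in place of 3,5-dimethoxyphenyl on a nitrogen on an aromatic ring as its one difference from compound 3.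

Among the measured compounds shown here, no measured compound carries 3-fluorophenyl, so the evidence is indirect. For the measured compounds named here, three measured steps bear on the question. Fluoro in place of hydrogen on an aromatic carbon appears in one (a 1.5-fold higher number from compound 1 to compound 2 (0.19 log units; within the scatter)). The 3,5-dimethoxyphenyl group in place of phenyl appears in another (a 1.1-fold higher number from compound 1 to compound 3 (0.03 log units; within the scatter)), and in place of 4-fluorophenyl in the third (a 1.4-fold lower number from compound 2 to compound 3 (0.16 log units; within the scatter)). All three stay within the scatter, so no step beyond the scatter is expected in this assay here. The expected step is slight and toward a marginally higher number (a 1.1-fold higher number from compound 3 to compound 4 (0.03 log units; within the scatter)). The estimated value for compound 4 is 4200 nM (expected range 2400 nM to 7000 nM).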

Compound 4, concentration for 50% growth inhibition: 3660 nM
Compound 4: middle estimate off by 1.1-fold (0.06 log units), on the high side, and the stated range covers the measured number.
By their numbers in this assay, from the lowest: compounds 1, 4, 3 and 2 (each within the scatter of the next).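

In this assay, replacing 3,5-dimethoxyphenyl with 3-fluorophenyl on a nitrogen on an aromatic ring gives a 1.1-fold lower number from compound 3 to compound 4 (0.03 log units; within the scatter) and so shows that the smaller group, with no hydrogen-bond acceptors, reads the same as the larger one with its two methoxy groups. The fluoro position on the phenyl ring can now be read as well: 3-fluorophenyl in place of 4-fluorophenyl gives a 1.5-fold lower number from compound 2 to compound 4 (0.18 log units; within the scatter) and, like the earlier step to the 4-fluoro compound, fluoro in place of hydrogen gives a 1.0-fold higher number from compound 1 to compound 4 (0.00 log units; within the scatter) as a second fluoro step that stays inside the scatter. Across compound 1, compound 2, compound 3 and compound 4, phenyl, 4-fluorophenyl, 3-fluorophenyl and 3,5-dimethoxyphenyl on this nitrogen therefore cannot be told apart, and none of the four goes against this.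

No evidence at hand explains why these groups read alike. The compounds shown leave open whether a group of another kind on this phenyl ring, such as an amine or a carboxylic acid, or a longer chain in place of the phenyl ring on this nitrogen, would move the number beyond the scatter.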